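Chloro to Trifluoromethyl on the Hydrazone Aryl Ring

This account rests on a few compounds, and the source may have more. Where it says the series, first, only, none or still open, it means among the compounds named here.

Compound 1: `CC(=O)/C(=N\Nc1ccccc1C(F)(F)F)Nc1cccc(Cl)c1`, in an assay on isolated protein for binding affinity to corticotropin-releasing factor receptor 1 (Homo sapiens) (a higher number here means a weaker inhibitor, a lower number a stronger inhibitor), compound 1 gives 538 nM; 538 nM (2 entries).
Compound 2: `COc1cccc(N/C(=N/Nc2ccccc2Cl)C(C)=O)c1`, in this assay compound 2 gives 652 nM.

The two measured compounds share a core and carry a chloro or a trifluoromethyl group on the aryl ring attached to the hydrazone nitrogen, with a chloro or a methoxy group on the other aryl ring. Their two values lie close to one another, within the usual scatter of this assay. Among the compounds with values here, compound 2 stands on the only number it has in this assay; a further entry for it gives no single number.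

Compound 3 is `COc1cccc(N/C(=N/Nc2ccccc2C(F)(F)F)C(C)=O)c1`. It differs from compound 2 in one place: trifluoromethyl in place of chloro on an aromatic carbon, on an aromatic carbon of a six-membered aromatic ring of carbon only, ortho to a large group. Within the data shown here, no pair of measured compounds shows this exact exchange on its own. Compound 1, which carries the trifluoromethyl group with a chloro elsewhere, sits at a value close to that of compound 2, so the exchange is expected to bring no step beyond the scatter in this assay. Compound 3 is therefore estimated at 560 nM, within a range of 250 nM to 1300 nM, which is expected to mean a step from compound 2 to compound 3 of a 1.2-fold lower number from compound 2 to compound 3 (0.07 log units; within the scatter).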

Compound 3, inhibition constant: 6950 nM
Compound 3: the middle estimate sits 12-fold (1.09 log units) below what was measured, outside the stated range (above it).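

Exchanging chloro for trifluoromethyl on the aromatic carbon ortho to a large group is not a neutral change when methoxy sits on the other aryl ring: in this assay, it brings an 11-fold higher number from compound 2 to compound 3 (1.03 log units; beyond the scatter), so compound 3 is the weaker inhibitor of the pair. The trifluoromethyl group alone does not fix the value at this position, since compound 1, which carries it with chloro on the other aryl ring, gives 538 nM; 538 nM (2 entries), whereas compound 3, which carries it with methoxy there, gives 6950 nM. Among these compounds, the outcome of having trifluoromethyl here therefore differs with the group on the other ring, but nothing shown here accounts for that difference.

The compounds shown leave open how a fluoro or a methyl group would compare with chloro and trifluoromethyl at this position when methoxy sits on the other ring. They also leave open whether an ethoxy group or a hydroxyl group on that other ring would follow compound 1 or compound 3 once trifluoromethyl is present.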